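The source may hold more compounds than are shown below. What is called first, only, known or untested is meant among the compounds shown, and "the series" means these compounds.

Measured so far:
- compound 1, `Cc1cc(O)cc(-c2nn(CC#N)cc2-c2ccnc(-c3ccc(Oc4ccccc4)cc3)c2)c1`: 98%
- compound 2, `COc1cc(C)cc(-c2nn(CC#N)cc2-c2ccnc(-c3ccc(N(C)C)cc3)c2)c1`: 95%

Both numbers come from a functional assay on ACHN cells (Homo sapiens) for cytotoxicity, read by sulforhodamine B assay, with a stated time of 48 h, tested at 0.001 uM; on this read-out higher numbers stand for a weaker effect at the one concentration tested and lower numbers for a stronger effect. Compound 2 gives the lower of the two values, but compound 1 lies only a few points higher, a gap within the scatter of repeated runs, so no order can be drawn between them. Both sit near the top of the scale, where the read-out stands for little effect at the single concentration tested.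

Compound 3, `Cc1cc(O)cc(-c2nn(CC#N)cc2-c2ccnc(-c3ccc(N(C)C)cc3)c2)c1`, is not yet measured. It differs from compound 2 in one place: hydrogen in place of methyl on an oxygen on an aromatic ring. Cut one bond further out, the same difference reads methoxy to hydroxy, the 3-methoxy-5-methylphenyl becoming 3-hydroxy-5-methylphenyl. Compound 1 already carries that hydroxy group but differs elsewhere as well, so it gives no direct comparison; its value only shows that a hydroxy-bearing analogue also sits near the top of the scale.

Among the measured compounds shown here, no step between measured compounds exists in this set, so the size of this step is unknown from data. Since both measured values lie within the scatter of each other near the top, a change no larger than the scatter is expected in this assay, with no clear direction; the expected step is no change at the digits printed from compound 2 to compound 3 (within the scatter). Compound 3 is estimated at 95%, with a range from 85% to 100%.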

Compound 3, a percentage reported as activity, at one concentration (the size of the read-out at that concentration, not a potency): 94%
For compound 3 the middle estimate is 1 percentage points above the measured one; the measured number falls inside the stated range.
By their numbers in this assay, from the lowest: compounds 3, 2 and 1 (each within the scatter of the next).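

In this assay, among the compounds shown here, methoxy to hydroxy on the 3-methoxy-5-methylphenyl gives a number 1 percentage points lower from compound 2 to compound 3 (within the scatter) and is the first direct reading of this change, so hydrogen in place of methyl on this oxygen has no effect that can be told apart from the scatter. With the hydroxy group held constant, dimethylamino in place of phenoxy on an aromatic carbon gives a number 4 percentage points lower from compound 1 to compound 3 (within the scatter) and thus adds a second single-place comparison, also without a separable effect in this assay. Neither of the two changes therefore moves the read-out away from the top of the scale at the single concentration tested, and nothing available bears on why the values stay together.

The compounds shown leave open whether a longer chain on this oxygen, such as ethoxy, or an amine or a carboxylic acid in place of the hydroxy group would give a step beyond the scatter. They also leave open whether the methoxy and hydroxy analogues would still read alike at concentrations where the read-out lies well away from the top of the scale.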